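Compound 2 and its unmeasured neighbour, compound 4

The source may hold more compounds than are shown below. What is called first, only, known or untested is meant among the compounds shown, and "the series" means these compounds.

Measured so far in an ADME assay (liver) for metabolic stability, with Liver microsome (Rattus norvegicus) as the target, read by LC-MS, using microsomes and NADPH, with stated times of 5 min and 60 min, tested at 4 uM (on this read-out higher numbers stand for a more stable compound and lower numbers for a less stable compound), for three compounds:
compound 1 `Cc1c(OCCCCOCOc2ccc(C(=O)O)cc2)ccc(C(=O)CC2CCCC2)c1O` gives 31%
compound 2 `Cc1c(OCCCCOc2ccc(F)c(C(=O)O)c2)ccc(C(=O)CC(C)(C)C)c1O` gives 58%
compound 3 `COc1ccc(C(=O)O)cc1OCCCCOc1ccc(C(=O)CC2CCCC2)c(O)c1C` gives 14%

Compound 2 stands highest of the three, and its gaps to compound 1 and compound 3 both lie beyond the scatter. Those gaps are a poor guide, however, since compound 2 differs from each of the other two in more than one place.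

Compound 4 `Cc1c(OCCCCOc2ccc(C(=O)CC(C)(C)C)c(O)c2C)cccc1C(=O)O` has not yet been measured. It differs from compound 2 in a single group, and the rest of the structure is shared: 3-carboxy-2-methylphenyl in place of 3-carboxy-4-fluorophenyl on an oxygen on a saturated carbon (3-carboxy-2-methylphenyl in place of 3-carboxy-4-fluorophenyl, on an oxygen on a saturated carbon).

Among the measured compounds shown here, only one measured step bears on this place: a number 17 percentage points lower from compound 1 to compound 3 (beyond the scatter), where 5-carboxy-2-methoxyphenyl replaces (4-carboxyphenoxy)methyl. For the measured compounds named here, that step is modest and involves different groups, and no measured step exchanges the two groups at issue here, so it offers only weak guidance. On that basis, a modest fall is expected rather than a rise, and the estimated change is a number 12 percentage points lower from compound 2 to compound 4 (beyond the scatter) in this assay overall. The estimate for compound 4 is 46%, with an expected range from 27% to 65% as its likely span.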

Compound 4, percent of the compound remaining: 51%
For compound 4 the middle estimate is 5 percentage points below the measured one; low and high end bracket the measured number.
By their numbers in this assay, from the lowest: compound 3; then compound 1; then compounds 4 and 2 (each within the scatter of the next).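

In this assay, putting 3-carboxy-2-methylphenyl in place of 3-carboxy-4-fluorophenyl on an oxygen on a saturated carbon gives a number 7 percentage points lower from compound 2 to compound 4 (within the scatter), so this read-out does not tell the two groups apart. The earlier compounds shown here offered only a number 17 percentage points lower from compound 1 to compound 3 (beyond the scatter), an exchange of different groups at the same place, and the new pair shows that not every exchange there moves the number beyond the scatter. Here the fluorine leaves and an eighth carbon enters the group, while the group's ring, its carboxylic acid and the rest of the structure stay the same, and the number stays within the scatter; no measurement shown here offers an explanation for this result.

The compounds shown leave open whether this place needs the carboxylic acid at all, since each of them carries one and none has a primary amide or a tetrazole there instead. They also leave open whether the same exchange would stay within the scatter with the cyclopentyl group of compound 1 and compound 3 in place of the tert-butyl group of compound 2 and compound 4.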